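This account rests on a few compounds, and the source may have more. Where it says the series, first, only, none or still open, it means among the compounds named here.

Measured so far:
compound 1, `C[Si](C)(C)c1ccc(CNC(=S)NCc2ccc(NS(C)(=O)=O)cc2)cc1`, > 100000 nM
compound 2, `CC[Si](C)(C)c1ccc(CNC(=S)NCc2ccc(NS(C)(=O)=O)cc2)cc1`, > 100000 nM

In a functional assay on cells (strain Sprague-Dawley) for agonist activity at transient receptor potential cation channel subfamily V member 1 (Rattus norvegicus), read by scintillation counting (a higher number here means that more compound is needed for the effect, a lower number that less compound is needed), compound 1 gives only a limit, > 100000 nM. Compound 2 likewise gives only a limit in this assay, > 100000 nM. The step that the two limits leave unreadable from compound 1 to compound 2 is therefore not readable in size or direction. Within the data shown here, compound 2 thus stands at a limit, and the one further value shown is also a limit (the limit of > 100000 nM in this assay, at which 2 of the 2 values shown sit).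

Compound 3, `CC[Si](CC)(CC)c1ccc(CNC(=S)NCc2ccc(NS(C)(=O)=O)cc2)cc1`, differs from compound 2 by a group of 7 heavy atoms (6 carbon, 1 silicon; no ring) in place of a group of 5 heavy atoms (4 carbon, 1 silicon; no ring), on an aromatic carbon. Among the measured compounds shown here, the single measured step is the only one that bears on this change, and it yields no readable size. With nothing shown that moves a value off the limit, the expectation for this assay is no readable step, a step that the limit leaves unreadable from compound 2 to compound 3, and compound 3 is expected to return a limit as well. Compound 3 is estimated at 200000 nM, in a range from 50000 nM to 1000000 nM.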

Compound 3, half-maximal effective concentration: > 100000 nM
Compound 3 gave a limit, no number; the forecaster's own chance of this, stated with the estimate: 85%; the middle value lies beyond the limit too.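

Compound 3 gives only a limit in this assay, > 100000 nM, so no step from compound 1 or compound 2 to compound 3 can be read: the limit of > 100000 nM in this assay, at which 3 of the 3 values shown sit.

The compounds shown leave open whether the change of group on the aromatic carbon moves the value at all.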